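The compounds below may be only part of what the source reports. "The series", "measured", "known", "first", "only" and "open" are said of these compounds alone.

Working notes on a thiosemicarbazide series

Of the compounds shown here, three have been measured in a functional assay on A549 cells (Homo sapiens) for inhibition, read by colorimetric assay and MTT assay, with a stated time of 72 h; a lower number here means a stronger inhibitor, a higher number a weaker inhibitor. Compound 1 `O=C(NNC(=S)Nc1csc(-c2ccccc2)c1)c1ccc(O)cc1` gives 75000 nM. Compound 2 `Cc1ccc(-c2cc(NC(=S)NNC(=O)c3ccc(O)cc3)cs2)cc1` gives 44000 nM; the change from compound 1 to compound 2 is methyl in place of hydrogen on an aromatic carbon, and the step it makes is a 1.7-fold lower number from compound 1 to compound 2 (0.23 log units; within the scatter). Compound 3 `COc1ccc(C(=O)NNC(=S)Nc2csc(-c3ccccc3)c2)cc1OC` gives 20000 nM, the lowest of the three numbers; its gap to compound 2 and its gap to compound 1 both lie beyond the scatter. The difference between the core of compound 1 and the core of compound 3 is not broken down here.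

Compound 4 `COc1ccc(C(=O)NNC(=S)Nc2csc(-c3ccc(C)cc3)c2)cc1OC` is not yet measured. It stands to compound 3 as compound 2 stands to compound 1: the change is methyl in place of hydrogen on an aromatic carbon, and its place reads the same, word for word, as the place of the change from compound 1 to compound 2, so this counts as the same change made on the other core. Within the data shown here, the one measured instance of it, from compound 1 to compound 2, stayed within the scatter, which gives little reason to expect a large move on the core of compound 3. A step of about a 1.5-fold lower number from compound 3 to compound 4 (0.19 log units; within the scatter) is therefore expected, of the same order as the step from compound 1 to compound 2, because that earlier step was a 1.7-fold lower number from compound 1 to compound 2 (0.23 log units; within the scatter). On that basis compound 4 is estimated at 13000 nM in this assay, with a plausible range from 6000 nM to 30000 nM; whether a single methyl transfers its effect across cores rests on one pair only.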

Compound 4, half-maximal inhibitory concentration: 36000 nM
For compound 4 the middle estimate is 2.8-fold (0.44 log units) below the measured one; measured number above the stated range.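

In this assay the exchange of hydrogen for methyl on the core of compound 3 gives a 1.8-fold higher number from compound 3 to compound 4 (0.26 log units; within the scatter) and so does not repeat the direction seen on the core of compound 1. Set side by side, the two steps run opposite ways, and the gap between them is larger than scatter alone would readily account for: the same change on two cores in this assay, a 1.7-fold lower number (0.23 log units; within the scatter) from compound 1 to compound 2 and a 1.8-fold higher number (0.26 log units; within the scatter) from compound 3 to compound 4, 3.1-fold (0.49 log units) apart, beyond the scatter of two such steps. This shows that, for these two cores, the change from phenyl to 4-methylphenyl cannot be carried over as a fixed increment, but each step taken alone stays within the scatter, so it does not show that methyl helps on one core or harms on the other, and with one pair per core it gives no general rule for the series and no explanation for the gap.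

The compounds shown hold only hydrogen or methyl at this place, so it remains open how a fluorine, a chlorine, an ethyl chain or an amine would behave there on either core. Going by these compounds, it also remains open whether the same change on a third core would follow the step on the core of compound 1, the step on the core of compound 3, or neither.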